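The source may report more compounds than this note shows. Statements on the series, on what has been measured and on what is new or still open speak of the compounds shown alone.

Working notes on the amide series.

In a functional assay on KG-1 cells (Homo sapiens) for cytotoxicity, read by luminescence and CellTiter-Glo, with a stated time of 3 days (a lower number here means a stronger inhibitor, a higher number a weaker inhibitor), compound 2 `N#Cc1ccc(NC(=O)c2ccc(F)cc2O)cc1` gives 3150 nM. Compound 3 `O=C(Nc1ccc(C(F)(F)F)cc1)c1ccc(F)cc1O` gives 740 nM in this assay. Compound 1 `CN(C(=O)c1cc(F)ccc1O)c1ccc(C#N)cc1` gives > 10000 nM in this assay, which is a limit of the assay and not a number. Of the two numbers in hand, compound 2 stands highest; its nearest neighbour is compound 3, reached by a 4.3-fold lower number from compound 2 to compound 3 (0.63 log units; beyond the scatter), trifluoromethyl in place of cyano on an aromatic carbon.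

Compound 4 `N#Cc1ccc(NC(=O)c2ccccc2O)cc1` is not yet measured. It differs from compound 2 by hydrogen in place of fluoro on an aromatic carbon. For the measured compounds named here, none of the measured steps touches the fluoro: the one available step, a 4.3-fold lower number from compound 2 to compound 3 (0.63 log units; beyond the scatter), concerns an exchange of a different group and gives no guidance on removing fluoro. For this assay the expectation is therefore a step no larger than the scatter, direction open, with compound 2 as the anchor. Compound 4 is expected to give about 4500 nM, within a range of 1800 nM to 12000 nM. The step this estimate implies is a 1.4-fold higher number from compound 2 to compound 4 (0.15 log units; within the scatter), which is expected to stay within the scatter.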

Compound 4, half-maximal inhibitory concentration: 5370 nM
Compound 4: the middle estimate sits 1.2-fold (0.08 log units) below what was measured; the measured number falls inside the stated range.
By their numbers in this assay, from the lowest: compound 3; then compounds 2 and 4 (each within the scatter of the next). At a limit, above all of these: compound 1.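

Hydrogen in place of fluoro on this aromatic carbon, meta to a hydroxy group and para to a large group, gives in this assay a 1.7-fold higher number from compound 2 to compound 4 (0.23 log units; within the scatter). The fluoro can therefore go without a difference that this assay can resolve, and compound 2 and compound 4 cannot be told apart. For the compounds shown here, the only earlier step, a 4.3-fold lower number from compound 2 to compound 3 (0.63 log units; beyond the scatter), changed a different place, so this is the first reading at this carbon, and it is a single replacement on a single background.

On these data alone, whether a chlorine, a methoxy group or an amine on this carbon would stay as close to compound 2, and whether the same exchange holds with trifluoromethyl in place of cyano, remains open. Any replacement that costs much activity could not be sized, as the read-out ends at a limit: the limit of > 10000 nM in this assay, at which 1 of the 4 values shown sits.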